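Fluorinated cinnamoyl analogues: from compound 3 to compound 4

The source may hold more compounds than are shown below. What is called first, only, known or untested is meant among the compounds shown, and "the series" means these compounds.

Measured compounds:
Compound 1 `CC1=C(/C=C/C(=O)/C=C/c2cccc(C(F)(F)F)c2)C(C)(C)CCC1O`: 2600 nM
Compound 2 `CC1=C(/C=C/C(=O)/C=C/c2ccccc2F)C(C)(C)CCC1O`: "not determined" (no result reported)
Compound 3 `CC1=C(/C=C/C(=O)/C=C/c2ccc(F)cc2)C(C)(C)CCC1O`: "not determined" (no result reported)

Going by the values given here, in a functional assay on PCa 2b cells (Homo sapiens) for cytotoxicity, read by MTT assay, with a stated time of 72 h (a higher number here means a weaker inhibitor, a lower number a stronger inhibitor), compound 1 gives 2600 nM, and it is the only compound of the set with a number. Compound 2 and compound 3 both carry a single fluoro group on the aromatic ring and share the core of compound 1, but neither has a number in this assay: compound 2 gives "not determined" (no result reported), and compound 3 gives "not determined" (no result reported). Compound 3 therefore stands without a number, alongside one further entry, compound 2, that also has none.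

Compound 4 `CC1=C(/C=C/C(=O)/C=C/c2ccc(F)c(C(F)(F)F)c2)C(C)(C)CCC1O` differs from compound 3 by trifluoromethyl in place of hydrogen on an aromatic carbon. Among the compounds with values here, since compound 3 has no value, no step from it can be sized. The nearest anchor is compound 1, which also bears a trifluoromethyl group on the aromatic ring and gives 2600 nM in this assay. Compound 4 is expected to land close to that anchor, with no step beyond the scatter of this assay predicted from the data at hand. For compound 4 the estimated value in this assay is 2600 nM, with a range from 900 nM to 7500 nM.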

Compound 4, half-maximal inhibitory concentration: 10000 nM
Beside the measured number, compound 4's estimate is 3.8-fold (0.59 log units) below it; measured number outside the range, above it.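

In this assay the set now holds its first readable step, a 3.8-fold higher number from compound 1 to compound 4 (0.59 log units; beyond the scatter), with fluoro in place of hydrogen on an aromatic carbon of the ring that already carries trifluoromethyl. Trifluoromethyl ortho to a fluoro group therefore reads as a modestly weaker inhibitor than trifluoromethyl on a ring with no fluoro group, and the shift lies beyond the scatter. No measurement at hand gives a reason for this shift.

Steps from compound 2 and compound 3 cannot be read, since neither has a number, so what trifluoromethyl itself adds to a fluorinated ring stays unsized. Also open, on these data alone, is how an amine or a methoxy group on that same aromatic carbon would compare in this assay with compound 4.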